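A few compounds are considered here, and "the series" means these few. Any claim that something is new, unique, unknown or untested is made for them only; others in the source may bear on it.

Working notes on the series. In an ADME assay on microsomes from liver (Homo sapiens) for metabolic stability, using NADPH, with a stated time of 10 min (on this read-out higher numbers stand for a more stable compound and lower numbers for a less stable compound), compound 1 `NC/C=C\CN(C[C@H]1Cc2ncccc2CN1)[C@H]1CCCc2cccnc21` gives 85%. Compound 2 `CCN(CC)CCCCN(C[C@H]1Cc2ncccc2CN1)[C@H]1CCCc2cccnc21` gives 80%, which places it within the scatter of compound 1, so the two cannot be ranked. Among the compounds with values here, these are the only two numbers available for the series.

Compound 3 `CN(CCCCN(C[C@H]1Cc2ncccc2CN1)[C@H]1CCCc2cccnc21)C1CCOCC1` retains the shared core of compound 2 and differs in one place: methyl(oxan-4-yl)amino in place of diethylamino on a saturated chain carbon, four bonds along the chain from an amine nitrogen. In words, methyl(oxan-4-yl)amino stands in place of diethylamino on a saturated chain carbon, four bonds along the chain from an amine nitrogen.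

Within the data shown here, no measured compound carries the oxan-4-yl ring, so the data contain no direct precedent for this change. Among the measured compounds shown here, the only measured step that bears on it is a number 5 percentage points lower from compound 1 to compound 2 (within the scatter). That exchange also involved an amine-bearing group, but a single step within the scatter is thin evidence. As far as these compounds go, no clear shift in this assay is therefore expected, and the direction remains open. The expected step is a number 2 percentage points lower from compound 2 to compound 3 (within the scatter), which is estimated to stay within the scatter. For compound 3 the estimated value is 78%, with an expected range of 62% to 92%.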

Compound 3, percent of the compound remaining: 100%
Compound 3: middle estimate off by 22 percentage points, on the low side; measured number outside the range, above it.
By their numbers in this assay, from the lowest: compounds 2 and 1 (each within the scatter of the next); then compound 3.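

In this assay, within the data shown here, the group on a saturated chain carbon, four bonds along the chain from an amine nitrogen, proves able to move the read-out: the change to methyl(oxan-4-yl)amino gives a number 20 percentage points higher from compound 2 to compound 3 (beyond the scatter), whereas the only earlier step gave a number 5 percentage points lower from compound 1 to compound 2 (within the scatter). The comparison with the other open-chain compound agrees in direction, with a number 15 percentage points higher from compound 1 to compound 3 (beyond the scatter), although that step exchanges a larger part of the side chain, so it says less about the amine substituent alone. No measurement here bears on the reason for this rise.

The compounds shown do not separate the contribution of the ring oxygen from that of the six-membered ring itself, or from the exchange of the ethyl groups for a methyl group and a ring; cyclohexyl(methyl)amino or morpholin-4-yl at the same place would bear on that question. As far as these compounds go, it also remains open whether the same exchange keeps its effect on a longer chain between the two amine nitrogens.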